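Swapping Methylphenyl for Pyridinyl on the Amide Nitrogen

This account rests on a few compounds, and the source may have more. Where it says the series, first, only, none or still open, it means among the compounds named here.

Three compounds share one core and differ only in the aromatic group carried by the amide nitrogen. In a functional assay on the whole organism (strain Wistar) for inhibition, with Rattus norvegicus as the target, read by paw edema, with a stated time of 24 h, at a dose of 100 mg/kg (on this read-out lower numbers stand for less inhibition and higher numbers for more inhibition at the one dose given (going by the name of the read-out)), compound 1 `COc1cc2c(cc1OC)C(CC(=O)Nc1ccccc1C)CC2` gives 23.3%. Compound 2 `COc1cc2c(cc1OC)C(CC(=O)Nc1cccc(C)c1)CC2` gives 41.7%, and compound 3 `COc1cc2c(cc1OC)C(CC(=O)Nc1ccc(C)cc1)CC2` gives 30%. Moving the methyl on that ring gave a number 18.4 percentage points higher from compound 1 to compound 2 (beyond the scatter), whereas a number 6.7 percentage points higher from compound 1 to compound 3 (within the scatter), and a number 11.7 percentage points lower from compound 2 to compound 3 (beyond the scatter). Compound 3 thus stands second of the three numbers, close to compound 1 and below compound 2.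

Compound 4 `COc1cc2c(cc1OC)C(CC(=O)Nc1ccccn1)CC2` carries pyridin-2-yl in place of 4-methylphenyl on an amide-type nitrogen. Going by the values given here, none of the measured steps touches a change of this kind: each of them only shifts a methyl around a ring of carbon, none exchanges the ring itself. Among the compounds with values here, there is therefore no step to lean on, and the expectation can only be that compound 4 lands within the spread already seen. Compound 4 is estimated at 30%, with a range from 12% to 50%. That estimate means a step of no change at the digits printed from compound 3 to compound 4 (within the scatter) is expected, nothing beyond the scatter.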

Compound 4, a percentage reported as inhibition, in the whole organism at one dose (the size of the read-out at that dose, not a potency): 33.3%
Compound 4: the middle estimate sits 3.3 percentage points below what was measured; the range from low to high includes it.
By their numbers in this assay, from the lowest: compounds 1, 3, 4 and 2 (each within the scatter of the next, the first and the last beyond it).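

Replacing the 4-methylphenyl ring with pyridin-2-yl on the amide-type nitrogen brings a ring nitrogen and one hydrogen-bond acceptor, a kind of change the methyl shifts did not cover, yet in this assay it gives (a number 3.3 percentage points higher from compound 3 to compound 4 (within the scatter)). Compound 4 also cannot be separated from the other two amides (a number 8.4 percentage points lower from compound 2 to compound 4 (within the scatter); a number 10 percentage points higher from compound 1 to compound 4 (within the scatter)), even though compound 1 and compound 2 differ beyond the scatter, so this place accepts a ring of a different kind without a clear loss or gain at this one dose. No measurement on hand accounts for this result.

From the compounds shown here alone, a plain phenyl ring, or a phenyl ring carrying an amine or a carboxylic acid, remains open at this place. So does the effect of adding a methyl to the pyridin-2-yl ring.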